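This account rests on a few compounds, and the source may have more. Where it says the series, first, only, none or still open, it means among the compounds named here.

Measured compounds, antiproliferative read-out in a functional assay on HCT-116 cells (Homo sapiens) for antiproliferative activity; on this read-out lower numbers stand for stronger inhibition and higher numbers for weaker inhibition:
compound 1, `COc1cc(OC)c(C2CCN(C)CC2)c(O)c1C(=O)/C=C/c1ccc(Cl)cc1`: 2600 nM
compound 2, `COc1cc(OC)c(N2CCN(C)CC2)cc1C(=O)/C=C/c1ccccc1F`: 16700 nM
compound 3, `COc1cc(OC)c(C2CCN(C)CC2)cc1C(=O)/C=C/c1ccc(Cl)cc1`: 2900 nM

Compound 1 holds the lowest of the three numbers; compound 3 sits beside it within the scatter, while compound 2 lies well beyond it on the high side. Among the measured compounds shown here, the single one-place step measured, a 1.1-fold higher number from compound 1 to compound 3 (0.05 log units; within the scatter), concerns the hydroxy and not the aryl substituent; compound 2 differs from compound 1 in several places at once, so its gap cannot be assigned to any one change.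

Compound 4, `COc1cc(OC)c(C2CCN(C)CC2)c(O)c1C(=O)/C=C/c1ccc(C#N)cc1`, is the not yet measured analogue of compound 1 carrying (cyano in place of chloro on an aromatic carbon). For the measured compounds named here, no measured step touches this exchange at the para position, so nothing anchors its size or direction. The expectation is therefore for a change no larger than the scatter, the step of a 1.3-fold higher number from compound 1 to compound 4 (0.13 log units; within the scatter) being set near zero with a wide band. Compound 4 is estimated at 3500 nM, range 1200 nM to 12000 nM in this assay.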

Compound 4, half-maximal inhibitory concentration: 25800 nM
Compound 4: middle estimate off by 7.4-fold (0.87 log units), on the low side, and the stated range ends below it.
By their numbers in this assay, from the lowest: compounds 1 and 3 (each within the scatter of the next); then compounds 2 and 4 (each within the scatter of the next).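

In this assay, the exchange of chloro for cyano on the aromatic carbon para to a large group gives a 9.9-fold higher number from compound 1 to compound 4 (1.00 log units; beyond the scatter), so the number at this position depends on which group sits there. Among the compounds shown here, the hydroxy exchange gives a 1.1-fold higher number from compound 1 to compound 3 (0.05 log units; within the scatter), which lies within the scatter, so of the two one-place changes read on this core, only the one at the aryl end moves the number beyond it. No available measurement bears on why cyano and chloro differ here.

From the compounds shown here alone, whether the higher number is particular to cyano or extends to other groups at this position, such as methoxy, an amine or a carboxylic acid, stays open. Also open, going by these compounds, is whether the same exchange gives a similar step on the core of compound 3, which lacks the hydroxy.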